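This account rests on a few compounds, and the source may have more. Where it says the series, first, only, none or still open, it means among the compounds named here.

Measured so far, in a functional assay on K562 cells (Homo sapiens) for inhibition, read by sulforhodamine B assay, with a stated time of 48 h, tested at 10 uM; a higher number here means a weaker effect of the compound at the concentration tested, a lower number a stronger effect:
compound 1, `COc1cc(Cl)cc(-c2nn(-c3cccc(NC(=O)Nc4ccc(Cl)c(C(F)(F)F)c4)c3)cc2-c2ccncc2)c1`, gives 8.93%
compound 2, `COc1cc(Cl)cc(-c2nn(-c3cccc(NC(=O)Nc4cccc(C(F)(F)F)c4)c3)cc2-c2ccncc2)c1`, gives 7.61%
compound 3, `COc1cc(Cl)cc(-c2nn(-c3cccc(NC(=O)c4cccc(C(F)(F)F)c4)c3)cc2-c2ccncc2)c1`, gives 26%

Compound 3 stands highest of the three numbers, meaning the weakest effect at the tested concentration: the step is a number 17.1 percentage points higher from compound 1 to compound 3 (beyond the scatter) and a number 18.4 percentage points higher from compound 2 to compound 3 (beyond the scatter), both beyond the scatter and both arising where the amide of compound 3 replaces the urea of the other two. Compound 4, `COc1cc(Cl)cc(-c2nn(-c3cccc(NC(=O)c4cc(C(F)(F)F)cc(C(F)(F)F)c4)c3)cc2-c2ccncc2)c1`, differs from compound 3 by trifluoromethyl in place of hydrogen on an aromatic carbon, the new group entering meta to a trifluoromethyl group already present.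

Within the data shown here, no measured step alters this ring within an amide. Among the measured compounds shown here, the only step that changes a substituent on the outer aryl ring at all is a number 1.3 percentage points lower from compound 1 to compound 2 (within the scatter), where a chloro left a urea with no change beyond the scatter. On that slim basis compound 4 is expected to stay close to compound 3, with a number 1 percentage points lower from compound 3 to compound 4 (within the scatter). The estimate for compound 4 in this assay is 25%, expected between 8% and 45%.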

Compound 4, a percentage reported as activity, at one concentration (the size of the read-out at that concentration, not a potency): 38%
Beside the measured number, compound 4's estimate is 13 percentage points below it, within the range that was stated.
By their numbers in this assay, from the lowest: compounds 2 and 1 (each within the scatter of the next); then compound 3; then compound 4.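

On the outer aromatic ring of the amide, adding trifluoromethyl on a carbon meta to a trifluoromethyl group already present weakens the effect in this assay, with a number 12 percentage points higher from compound 3 to compound 4 (beyond the scatter). Among these compounds, this is the first measured step on this ring within an amide, and it shows that the read-out responds to a change here, whereas removing the chloro from the urea, with a number 1.3 percentage points lower from compound 1 to compound 2 (within the scatter), did not move the number beyond the scatter. Nothing available explains why the added group has this effect.

The compounds shown leave open whether a fluoro, a methoxy or an amino group on this same carbon would shift the number in the same direction. They also leave open whether a second trifluoromethyl would weaken the effect of a urea such as compound 2.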